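Benzyl Capping of the Ring Hydroxyl in Compound 3

The compounds below may be only part of what the source reports. "The series", "measured", "known", "first", "only" and "open" are said of these compounds alone.

compound 1 `NCC(N)CCCNC(=O)CCn1cccc(O)c1=O`: 12.2%
compound 2 `NCC(N)CCCCNC(=O)CCn1cccc(O)c1=O`: 12.1%

In a physicochemical assay, read by spectrophotometry, with a stated time of 10 min, tested at 0.02 mM, in the presence of a further agent that is not named here (on this read-out higher numbers stand for a stronger effect at the one concentration tested and lower numbers for a weaker effect), compound 1 gives 12.2% and compound 2 gives 12.1%. On the numbers shown compound 2 sits at the lower of the two, but the step of a number 0.1 percentage points lower from compound 1 to compound 2 (within the scatter) lies within the scatter, so the two are not distinguished. Compound 3 `NCC(N)CCCCNC(=O)CCn1cccc(OCc2ccccc2)c1=O` differs from compound 2 by benzyl in place of hydrogen on an oxygen on an aromatic ring. Within the data shown here, no measured step touches this oxygen; the only step available alters the diamine chain and does not bear on it. The estimate therefore rests on the change alone, an expected step of a number 7.1 percentage points lower from compound 2 to compound 3 (within the scatter) downward. Compound 3 is expected to give 5% within a range from 0% to 14%.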

Compound 3, a percentage reported as activity, at one concentration (the size of the read-out at that concentration, not a potency): 6.59%
Compound 3: the middle estimate sits 1.6 percentage points below what was measured; the measured number falls inside the stated range.
By their numbers in this assay, from the lowest: compounds 3, 2 and 1 (each within the scatter of the next).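

Capping the oxygen on the aromatic ring gives the first reading at this position. In this assay, among these compounds, benzyl in place of hydrogen gives a number 5.5 percentage points lower from compound 2 to compound 3 (within the scatter) and so leaves hydroxy to benzyloxy undistinguished from no change on this read-out, whereas the earlier compounds varied only the diamine chain. Nothing available here accounts for the result.

From the compounds shown here alone, what a methyl or a carboxymethyl on this oxygen would give remains open. So does whether benzyloxy would read the same with the 1,2-diaminoethyl chain of compound 1.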